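The source may report more compounds than this note shows. Statements on the series, on what has been measured and on what is new or still open speak of the compounds shown alone.

Working notes on the series. For the measured compounds named here, compound 1 `N#Cc1ccc(NC(=O)c2ccc(Cl)cc2O)cc1` is the only member of the set that returns a number in a functional assay on KG-1 cells (Homo sapiens) for cytotoxicity, read by luminescence and CellTiter-Glo, with a stated time of 3 days; on this read-out lower numbers stand for stronger inhibition and higher numbers for weaker inhibition: compound 1 gives 1920 nM. Compound 2 `N#Cc1ccc(NC(=O)c2ccc3ccccc3c2)cc1` is reported in this assay only as a limit, > 10000 nM, and not as a number. That boundary, (the limit of > 10000 nM in this assay, at which 1 of the 2 values shown sits), is where compound 2 sits, so compound 1 stands as the single quantified point of the pair, with compound 2 at the limit.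

Compound 3 `N#Cc1ccc(NC(=O)c2ccc(Br)cc2O)cc1` has not yet been measured in this assay. It differs from compound 1 in one place: bromo in place of chloro on an aromatic carbon. The hydroxy group, the amide and the rest of the core of compound 1 are kept as they are. Going by the values given here, no measured pair isolates this exchange, so the size of the step rests on the change alone. The expected step from compound 1 to compound 3 is a 1.2-fold lower number from compound 1 to compound 3 (0.08 log units; within the scatter), a shift not expected to exceed the usual scatter in either direction. Compound 3 is therefore estimated at 1600 nM, with a range from 700 nM to 3800 nM in this assay.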

Compound 3, half-maximal inhibitory concentration: 1450 nM
Estimate against measurement, compound 3: 1.1-fold (0.04 log units) above; the range from low to high includes it.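

The exchange of chloro for bromo on this aromatic carbon, meta to a hydroxy group and para to a large group, gives a 1.3-fold lower number from compound 1 to compound 3 (0.12 log units; within the scatter) in this assay. For the compounds shown here, this is the first comparison that isolates a single change, and it gives the series a second quantified compound: at this position, the read-out does not separate the two halogens, so a bromine can stand in for a chlorine with no change that can be read. Nothing measured in the material at hand bears on this exchange.

Because chloro and bromo are the only groups shown at this carbon and the two cannot be told apart, it remains open whether the read-out responds to this position at all, which a methyl group or an amine on the same carbon would help to settle. Going by these compounds, the hydroxy group is also kept unchanged in compound 1 and compound 3, so what it contributes remains open, as does whether a methoxy group in its place would hold the read-out.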